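A few compounds are considered here, and "the series" means these few. Any claim that something is new, unique, unknown or untested is made for them only; others in the source may bear on it.

Measured so far in an ADME assay on MT4 cells (Homo sapiens) for cytotoxicity, read by MTT assay; on this read-out higher numbers stand for lower toxicity in this test and lower numbers for higher toxicity in this test:
- compound 1 `COc1cc(OC)c2c(C(=O)/C=C(\O)C(=O)O)cn(Cc3ccc(F)cc3)c2c1`: 20700 nM
- compound 2 `COc1cc2c(C(=O)/C=C(\O)C(=O)O)cn(Cc3ccc(F)cc3)c2cc1OC`: 65500 nM
- compound 3 `CCOC(=O)/C(O)=C/C(=O)c1cn(Cc2ccc(F)cc2)c2cc(OC)cc(OC)c12`: 55400 nM

Compound 2 lies within the scatter of compound 3, and both numbers sit beyond the scatter above compound 1. So compound 2 belongs to the upper end of this small set, with higher numbers in this assay standing for lower toxicity in this test.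

Compound 4 `CCOC(=O)/C(O)=C/C(=O)c1cn(Cc2ccc(F)cc2)c2cc(OC)c(OC)cc12` has not yet been measured. It differs from compound 2 in one place: ethyl in place of hydrogen on an oxygen next to a carbonyl group. This is ethyl in place of hydrogen on an oxygen next to a carbonyl group, which turns carboxy into ethoxycarbonyl.

The same change has been measured once, on a different core: a 2.7-fold higher number from compound 1 to compound 3 (0.43 log units; beyond the scatter). For the measured compounds named here, that modest step is the only direct evidence, and one pair cannot show whether the change behaves alike on the core of compound 2. A step in the same direction, towards a higher number, is therefore expected in this assay, with a size similar to or somewhat smaller than that measured step. The expected change is a 2.0-fold higher number from compound 2 to compound 4 (0.30 log units; within the scatter). For compound 4 the estimated value is 130000 nM, with an expected range from 55000 nM to 300000 nM.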

Compound 4, half-maximal cytotoxic concentration: 21800 nM
The estimate for compound 4 lay 6.0-fold (0.78 log units) above the measured number; the whole stated range lies above it.
By their numbers in this assay, from the lowest: compounds 1 and 4 (each within the scatter of the next); then compounds 3 and 2 (each within the scatter of the next).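

In this assay, ethoxycarbonyl in place of carboxy gives a 3.0-fold lower number from compound 2 to compound 4 (0.48 log units; beyond the scatter), so on the core of compound 2 the ethyl group goes with a higher toxicity in this test, not a lower one. The earlier pair alone gave only the opposite direction, and the two pairs together show that this change has no single direction at this position: its direction differs with the core that carries it: the same change on two cores in this assay, a 2.7-fold higher number (0.43 log units; beyond the scatter) from compound 1 to compound 3 and a 3.0-fold lower number (0.48 log units; beyond the scatter) from compound 2 to compound 4, 8.0-fold (0.91 log units) apart, beyond the scatter of two such steps. A step measured on one core therefore cannot be carried over to the other in this series, neither in size nor in direction.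

With one pair on each of two cores, these compounds do not show which difference between the cores goes with the reversal, or whether any other core would follow either pair. Also open, on these data alone, is whether a methyl group, a longer chain on the same oxygen, or an amide in place of the carboxy group would follow the direction of the ethyl group on each core.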